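The source may report more compounds than this note shows. Statements on the series, on what has been measured and on what is new or still open speak of the compounds shown alone.

Compounds measured so far:
compound 1, `Cc1ccccc1C(=O)N(NC(=O)c1ccccc1)C(C)(C)C`, with 224 nM
compound 2, `Cc1ccccc1C(=O)NN(C(=O)c1ccccc1Cl)C(C)(C)C`, with 72.4 nM
compound 3, `CCCc1ccc(C(=O)NN(C(=O)c2ccccc2Cl)C(C)(C)C)cc1`, with 9.12 nM

All three were read in an assay on cells for agonist activity at ecdysone receptor (Bombyx mori), read by a luciferase reporter, with a stated time of 24 h; on this read-out lower numbers stand for an effect already at smaller amounts and higher numbers for an effect only at larger amounts of compound. Among the three numbers compound 2 stands second highest. Compound 1 gives 224 nM, a higher number than that of compound 2, and the gap lies beyond the scatter. Compound 3 gives 9.12 nM, a lower number than that of compound 2, and that gap too lies beyond the scatter.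

Compound 4, `CCCCCCC(=O)NN(C(=O)c1ccccc1Cl)C(C)(C)C`, has not yet been measured in this assay. It differs from compound 2 in one place: hexyl in place of 2-methylphenyl on a carbonyl carbon. For the measured compounds named here, no measured pair shows a change of this kind, and every measured compound keeps an aromatic ring on that carbonyl carbon, so the data give no direct guide. The step from compound 2 to compound 4 is therefore expected to go towards a higher number, and beyond the scatter, at about a 12-fold higher number from compound 2 to compound 4 (1.09 log units; beyond the scatter). On this basis compound 4 is estimated to give 900 nM in this assay, with a range from 150 nM to 6000 nM.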

Compound 4, half-maximal effective concentration: 741 nM
Estimate against measurement, compound 4: 1.2-fold (0.08 log units) above; the measured number falls inside the stated range.
By their numbers in this assay, from the lowest: compound 3; then compound 2; then compound 1; then compound 4.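

In this assay, for the compounds shown here, the carbonyl carbon whose other neighbour is the amide-type nitrogen carries a group without a ring for the first time, and this change is a large one: a 10-fold higher number from compound 2 to compound 4 (1.01 log units; beyond the scatter). By the computed counts the two groups are close in heavy atoms and neither has hydrogen-bond donors or acceptors, so the clearest difference between them is the loss of the aromatic ring, although a loss of the ring as the source of the step remains unproven. Nothing measured here accounts for the size of this step, and no supporting data bear on it.

The compounds shown rest on a single open chain at this position, so they leave open whether the step follows the missing ring or something particular to hexyl. A cyclohexyl group at this carbon would speak to the first possibility, while a shorter chain such as butyl or a longer one such as octyl would show whether the number in this assay moves with chain length.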